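A few compounds are considered here, and "the series" means these few. Any claim that something is new, unique, unknown or untested is made for them only; others in the source may bear on it.

Measured in a functional assay on A549 cells (Homo sapiens) for antiproliferative activity, read by MTT assay, with a stated time of 24 h; a lower number here means a stronger inhibitor, a higher number a weaker inhibitor:
- compound 1 `Cc1ccc(-c2nn(-c3ccccc3)cc2-c2nc3ccccc3n2S(=O)(=O)c2ccccc2)cc1`: 760 nM
- compound 2 `O=S(=O)(c1ccccc1)n1c(-c2cn(-c3ccccc3)nc2-c2ccc(F)cc2)nc2ccccc21`: 550 nM

Compound 2, at 550 nM, sits close to compound 1, at 760 nM. The measured change between them is a 1.4-fold lower number from compound 1 to compound 2 (0.14 log units; within the scatter), so these two values cannot be told apart, and compound 2 is best read as one of a matched pair.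

The next molecule, compound 3 `COc1ccc(S(=O)(=O)n2c(-c3cn(-c4ccccc4)nc3-c3ccc(F)cc3)nc3ccccc32)cc1`, keeps all of compound 2 except for one edit: methoxy in place of hydrogen on an aromatic carbon. Phenylsulfonyl thus becomes (4-methoxyphenyl)sulfonyl. Among the measured compounds shown here, only one measured step is available as a guide, a 1.4-fold lower number from compound 1 to compound 2 (0.14 log units; within the scatter), and it swaps fluoro in place of methyl rather than touching the phenylsulfonyl group. It shows that one edit to this series left the number within the scatter, but it says nothing direct about adding methoxy. With no evidence for a direction, no shift beyond the scatter is expected in this assay, and the expected change is a 1.1-fold lower number from compound 2 to compound 3 (0.02 log units; within the scatter). For compound 3 the estimated value is 520 nM, with an expected range of 210 nM to 1300 nM.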

Compound 3, half-maximal inhibitory concentration: 350 nM
Estimate against measurement, compound 3: 1.5-fold (0.17 log units) above; low and high end bracket the measured number.
By their numbers in this assay, from the lowest: compounds 3, 2 and 1 (each within the scatter of the next, the first and the last beyond it).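

Among the compounds shown here, this is the first step that touches the phenylsulfonyl group, since the earlier pair only swapped fluoro for methyl elsewhere in the molecule. In this assay, going from phenylsulfonyl to (4-methoxyphenyl)sulfonyl gives a 1.6-fold lower number from compound 2 to compound 3 (0.20 log units; within the scatter), so compound 2 and compound 3 cannot be told apart, and this carbon, para to a large group, can carry a methoxy without a shift beyond the scatter. No measurement is available that would explain this result.

As far as these compounds go, a single substituent says little about how this position responds in general, so it remains open whether an amine, a carboxylic acid or a longer chain such as butoxy in the same place would also leave the number within the scatter. From the compounds shown here alone, it is also open whether methoxy would read the same on another carbon of that ring, or whether the fluoro and methyl groups of compound 2 and compound 1 would behave alike alongside it.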